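The source may report more compounds than this note shows. Statements on the series, on what has been measured and on what is new or still open speak of the compounds shown alone.

compound 1 `C=CS(=O)(=O)NC/C=C/c1cc(OC)cc(O)c1C(=O)OC(C)C` gives 4660 nM
compound 2 `COc1cc(O)c(C(=O)OC(C)C)c(/C=C/CNC(C)=O)c1` gives > 10000 nM (a limit)
compound 3 `C=CS(=O)(=O)NC/C=C/c1cc(OC)cc(O)c1C(=O)OCc1ccc(F)cc1` is not yet measured

Among the measured compounds shown here, in a functional assay on MV4-11 cells (Homo sapiens) for antiproliferative activity, read by luminescence, with a stated time of 72 h (a higher number here means a weaker inhibitor, a lower number a stronger inhibitor), compound 1 gives 4660 nM and this is the only actual number so far. Compound 2 sits at > 10000 nM and that is a limit of the assay, not a number.

For the measured compounds named here, the change to follow is 4-fluorobenzyl in place of isopropyl on an oxygen next to a carbonyl group and it has no measured counterpart. Going by the values given here, the one measured step of an at least 2.1-fold higher number from compound 1 to compound 2 (0.33 log units; beyond the scatter) is acetyl in place of vinylsulfonyl on an amine nitrogen. That is a different place, so it sets neither size nor direction here.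

As far as these compounds go, with no guide, no shift beyond the scatter is expected in this assay and either direction stays open. The expected change is a 1.3-fold lower number from compound 1 to compound 3 (0.12 log units; within the scatter) and it is only an estimate. For compound 3 the expected value is 3500 nM with an estimated range from 900 nM to 10000 nM as its span.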

Compound 3, half-maximal inhibitory concentration: 5140 nM
Compound 3: the middle estimate sits 1.5-fold (0.17 log units) below what was measured; measured number inside the range.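

Among the compounds shown here, the step on the oxygen next to a carbonyl group, read in this assay, is a 1.1-fold higher number from compound 1 to compound 3 (0.04 log units; within the scatter), so this is the first measured change at this position and it does not separate the two groups. Isopropyl has 3 heavy atoms and no ring, whereas 4-fluorobenzyl has 8 heavy atoms and a six-membered aromatic ring, so for this pair the position accepts the larger group with no shift beyond the scatter. No measured property shown bears on this result.

As far as these compounds go, whether a carboxylic acid, or an amine carried on a longer chain in place of the isopropyl, would also leave the number within the scatter remains open. Also open, from the compounds shown here alone, is whether acetyl in place of vinylsulfonyl on the amine nitrogen has the same effect alongside 4-fluorobenzyl.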